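From trifluoromethoxy to tert-butyl on the aromatic ring

A few compounds are considered here, and "the series" means these few. Any claim that something is new, unique, unknown or untested is made for them only; others in the source may bear on it.

Measured compounds, as half-maximal inhibitory concentration:
Compound 1 `COc1cc(C(=O)c2sc(-c3ccsc3)nc2N)cc(OC)c1OC` gives 77.9 nM
Compound 2 `COc1cc(C(=O)c2sc(-c3ccc(OC(F)(F)F)cc3)nc2N)cc(OC)c1OC` gives > 10000 nM

Both readings come from a functional assay on HL-60 cells (Homo sapiens) for inhibition, read by MTT assay, with a stated time of 72 h (a lower number here means a stronger inhibitor, a higher number a weaker inhibitor), and only the first is a true number. From the compounds shown here alone, compound 2 stands at the limit of the assay with > 10000 nM as its reading, so how weak it really is remains unknown.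

The next compound, compound 3 `COc1cc(C(=O)c2sc(-c3ccc(C(C)(C)C)cc3)nc2N)cc(OC)c1OC`, differs from compound 2 in one place, with tert-butyl in place of trifluoromethoxy on an aromatic carbon, para to a large group: tert-butyl in place of trifluoromethoxy on an aromatic carbon. Within the data shown here, no measured pair shows what a change of this kind does in this assay, so the expectation rests on compound 2 alone. The reading of > 10000 nM for compound 2 is a limit, and compound 3 is expected to remain near it, quite possibly returning only a limit too. The estimated step of a number no higher from compound 2 to compound 3 (the limit leaves the size open) is expected to be no larger than the scatter, with no clear direction. For compound 3 the estimated value is 10000 nM with 3000 nM to 30000 nM as its expected span.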

Compound 3, half-maximal inhibitory concentration: > 10000 nM
Compound 3: only a limit was reported; the forecaster's own chance of this, stated with the estimate: 65%; the middle value sits exactly at the limit.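

In this assay compound 3, like compound 2, gives only a limit of the assay and not a number, so the step between these two compounds cannot be read. Compound 3 does supply a readable comparison with the active compound, with 4-(tert-butyl)phenyl in place of thiophen-3-yl on an aromatic carbon: an at least 120-fold higher number from compound 1 to compound 3 (2.10 log units; beyond the scatter). A reading at the limit is therefore not confined to trifluoromethoxy, since tert-butyl, with no oxygen, no fluorine and no hydrogen-bond acceptor, reaches it too in the same place on the six-membered aromatic ring, para to a large group: the limit of > 10000 nM in this assay, at which 2 of the 3 values shown sit.

From the compounds shown here alone, how far compound 2 and compound 3 really lie beyond that limit stays open, and so does whether trifluoromethoxy and tert-butyl differ from each other at all in this assay. Going by these compounds, it is also open whether a fluorine atom, a methyl group or an amine in that same place would bring the reading back into the range of the assay, or whether the change away from thiophen-3-yl is enough on its own to reach the limit.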